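A few compounds are considered here, and "the series" means these few. Any claim that something is new, unique, unknown or untested is made for them only; others in the source may bear on it.

Measured compounds:
compound 1 `O=C(Nc1ccc(Cl)cc1)c1cc(Oc2ccc(/C=C/c3ccccn3)cc2)ccn1` — 31300 nM
compound 2 `O=C(NC1CCCCC1)c1cc(Oc2ccc(/C=C/c3ccccn3)cc2)ccn1` — 20600 nM

Both compounds were tested in a functional assay on HepG2 cells (Homo sapiens) for antiproliferative activity, read by CCK-8 assay, with a stated time of 48 h; on this read-out lower numbers stand for stronger inhibition and higher numbers for weaker inhibition. Compound 2 gives the lowest of the two numbers, yet its neighbour, compound 1, sits only a 1.5-fold lower number from compound 1 to compound 2 (0.18 log units; within the scatter) away, so the two cannot be told apart on this read-out. That single step swaps cyclohexyl for 4-chlorophenyl on the amide-type nitrogen while keeping the amide hydrogen.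

Compound 3 `O=C(c1cc(Oc2ccc(/C=C/c3ccccn3)cc2)ccn1)N1CCCC1` is not yet measured. It differs from compound 2 by pyrrolidin-1-yl in place of cyclohexylamino on a carbonyl carbon. For the measured compounds named here, the only measured step, from compound 1 to compound 2, changes what the nitrogen carries but leaves the hydrogen-bond donor in place; here the donor is lost and the ring is closed onto the nitrogen. Going by the values given here, no measured step therefore speaks directly to this change, and the one that exists was within the scatter. Compound 3 is thus expected to show no step beyond the scatter, a 1.2-fold higher number from compound 2 to compound 3 (0.08 log units; within the scatter), with wide uncertainty. The estimate for compound 3 in this assay is 25000 nM, between 8000 nM and 80000 nM.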

Compound 3, half-maximal inhibitory concentration: 27000 nM
Compound 3: the middle estimate sits 1.1-fold (0.03 log units) below what was measured; the measured number falls inside the stated range.
By their numbers in this assay, from the lowest: compounds 2, 3 and 1 (each within the scatter of the next).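

In this assay, pyrrolidin-1-yl on the carbonyl carbon gives no separable result, with a 1.3-fold higher number from compound 2 to compound 3 (0.12 log units; within the scatter) against cyclohexylamino and a 1.2-fold lower number from compound 1 to compound 3 (0.06 log units; within the scatter) against (4-chlorophenyl)amino. For the compounds shown here, the earlier pair varied only what the amide-type nitrogen carried while the amide hydrogen stayed in place, whereas this change removes the hydrogen-bond donor and closes a ring onto the nitrogen, and still no step leaves the scatter. Among these three compounds, then, neither the loss of that donor nor the change from the six-membered carbon ring or the 4-chlorophenyl group to the five-membered ring can be read in this assay, and nothing available explains this result.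

The compounds shown leave open whether any other group on this carbonyl carbon, such as morpholine, piperazine or dimethylamino, would give a step beyond the scatter. They also leave open whether a change elsewhere on the shared core, such as an added amine or carboxylic acid, would separate the numbers where the groups on this carbonyl carbon do not.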